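The source may report more compounds than this note shows. Statements on the series, on what has been measured and on what is new or still open speak of the compounds shown alone.

Compound 1, `C[C@@H](Cn1ccc(-c2ccc(C#N)c(Cl)c2)n1)NC(=O)c1ccccc1`, gives 1830 nM in a functional assay on LNCaP cells (Homo sapiens) for antiproliferative activity, read by CCK-8 assay, with a stated time of 6 days; a lower number here means a stronger inhibitor, a higher number a weaker inhibitor.
Compound 2, `COC(=O)/C=C/C(=O)N[C@@H](C)Cn1ccc(-c2ccc(C#N)c(Cl)c2)n1`, gives 2460 nM in this assay.
Compound 3, `C[C@@H](Cn1ccc(-c2ccc(C#N)c(Cl)c2)n1)NS(=O)(=O)c1cn(C)cn1`, reaches only the limit of this assay, which stands at > 30000 nM.

The three compounds share one core and differ only in the group on the amine nitrogen. Compound 1 and compound 2 sit close together, as the step of a 1.3-fold higher number from compound 1 to compound 2 (0.13 log units; within the scatter) shows. Compound 3 stands apart: its value is a limit, not a number, and it marks the weak end of the set, since an at least 16-fold higher number from compound 1 to compound 3 (1.21 log units; beyond the scatter) and an at least 12-fold higher number from compound 2 to compound 3 (1.08 log units; beyond the scatter) are both large and beyond the scatter. This is the line (the limit of > 30000 nM in this assay, at which 1 of the 3 values shown sits).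

Compound 4, `C[C@@H](Cn1ccc(-c2ccc(C#N)c(Cl)c2)n1)Nc1cccnc1`, has not yet been measured in this assay. Its change from compound 3 is pyridin-3-yl in place of (1-methyl-1H-imidazol-4-yl)sulfonyl on an amine nitrogen. Going by the values given here, the steps that bear on it are those into compound 3, which show that removing the benzoyl or the (2-(methoxycarbonyl)ethenyl)carbonyl in favour of the sulfonyl group cost a great deal. Among the compounds with values here, replacing that sulfonyl group in turn may therefore be expected to recover part of the loss, though an aryl on the amine nitrogen has no measured precedent here. Compound 4 is expected to give about 6000 nM, within 1200 nM to 30000 nM. The estimated step is an at least 5.0-fold lower number from compound 3 to compound 4 (0.69 log units; beyond the scatter).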

Compound 4, half-maximal inhibitory concentration: 430 nM
Beside the measured number, compound 4's estimate is 14-fold (1.14 log units) above it; measured number below the stated range.
By their numbers in this assay, from the lowest: compound 4; then compounds 1 and 2 (each within the scatter of the next). At a limit, above all of these: compound 3.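

Alone among the four compounds, pyridin-3-yl puts a group without a carbonyl or sulfonyl on the amine nitrogen, and it gives the strongest inhibitor in this assay, with a 4.3-fold lower number from compound 1 to compound 4 (0.63 log units; beyond the scatter) and a 5.7-fold lower number from compound 2 to compound 4 (0.76 log units; beyond the scatter). The position therefore does not depend on the carbonyl of the benzoyl or (2-(methoxycarbonyl)ethenyl)carbonyl groups, and the weak end of the set belongs to the (1-methyl-1H-imidazol-4-yl)sulfonyl compound rather than to the shared core, as an at least 69-fold lower number from compound 3 to compound 4 (1.84 log units; beyond the scatter) shows. Compound 3 remains a limit and not a number, so that step gives only a bound: the limit of > 30000 nM in this assay, at which 1 of the 4 values shown sits.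

Going by these compounds, whether phenyl, pyridin-2-yl or pyridin-4-yl on the amine nitrogen would match pyridin-3-yl stays open, so the part played by the ring nitrogen cannot be told from these compounds. Also open, on these data alone, is whether the amine hydrogen matters, a question that a methyl group on that same nitrogen would address.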